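The source may report more compounds than this note shows. Statements on the series, on what has been measured and on what is new or still open speak of the compounds shown alone.

Series notes. Compound 1 `Oc1cccc(-c2cc(-c3cccc(F)c3)cc(-c3cccc(O)c3)n2)c1` and compound 3 `Oc1ccc(-c2cc(-c3cccc(F)c3)cc(-c3ccc(O)cc3)n2)cc1` carry different cores, and the difference between the two cores is not broken down here. In a functional assay on DU-145 cells (Homo sapiens) for inhibition (on this read-out lower numbers stand for stronger inhibition and higher numbers for weaker inhibition), compound 1 gives 23800 nM and compound 3 gives 9290 nM. Compound 2 `Oc1cccc(-c2cc(-c3ccc(F)cc3)cc(-c3cccc(O)c3)n2)c1` differs from compound 1 by 4-fluorophenyl in place of 3-fluorophenyl on an aromatic carbon; in this assay compound 2 gives 7120 nM, so that a 3.3-fold lower number from compound 1 to compound 2 (0.52 log units; beyond the scatter). The values of compound 2 and compound 3 lie within the scatter of each other. Compound 4 `Oc1ccc(-c2cc(-c3ccc(F)cc3)cc(-c3ccc(O)cc3)n2)cc1`, not yet measured, differs from compound 3 by 4-fluorophenyl in place of 3-fluorophenyl on an aromatic carbon. This is the same kind of change as that from compound 1 to compound 2, but the place differs: meta to two 4-hydroxyphenyl groups rather than meta to two 3-hydroxyphenyl groups. With a single earlier instance on another core, the direction is expected to carry over and the size to be somewhat smaller. The step is expected to be a 2.4-fold lower number from compound 3 to compound 4 (0.39 log units; beyond the scatter), set beside a 3.3-fold lower number from compound 1 to compound 2 (0.52 log units; beyond the scatter). That expectation rests on compound 1 giving 23800 nM and compound 2 giving 7120 nM. Compound 4 is therefore expected to give about 3800 nM in this assay, within a range from 1500 nM to 9500 nM.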

Compound 4, half-maximal inhibitory concentration: 6030 nM
The estimate for compound 4 lay 1.6-fold (0.20 log units) below the measured number; measured number inside the range.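

In this assay, 4-fluorophenyl in place of 3-fluorophenyl on the core of compound 3 gives a 1.5-fold lower number from compound 3 to compound 4 (0.19 log units; within the scatter), so on this core the effect of the change cannot be told apart from the scatter. The two instances of the change do not differ beyond what repeated measurements allow: the same change on two cores in this assay, a 3.3-fold lower number (0.52 log units; beyond the scatter) from compound 1 to compound 2 and a 1.5-fold lower number (0.19 log units; within the scatter) from compound 3 to compound 4, 2.2-fold (0.34 log units) apart, within the scatter of two such steps This shows no measurable dependence on the core, but it does not show that the clear step seen on the core of compound 1 is reproduced on the core of compound 3, and two pairs give no rule for any further core.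

The compounds shown leave open whether the same change would read alike with an amine or a methoxy group in place of the hydroxy groups. Also open, going by these compounds, is how a chlorine or a nitrile in place of the fluorine would read in this assay, on either core.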